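Cytotoxicity survey of the aminoimidazopyridine series, thiazolyl analogue pending

This account rests on a few compounds, and the source may have more. Where it says the series, first, only, none or still open, it means among the compounds named here.

Measured in an ADME assay on THP-1 cells (Homo sapiens) for cytotoxicity (on this read-out higher numbers stand for lower toxicity in this test and lower numbers for higher toxicity in this test), so far:
- compound 1, `c1cncc(-c2nc3ccccn3c2NC2CCCC2)c1`: gives > 50000 nM, a limit of the assay.
- compound 2, `Cc1cc(-c2nc3ccccn3c2NC2CCCC2)ccn1`: gives > 50000 nM, a limit of the assay.
- compound 3, `Fc1ccccc1-c1nc2ccccn2c1NC1CCCC1`: gives > 50000 nM, a limit of the assay.

Compound 3 thus stands at the upper limit of this assay, not at a number, and the same holds for every other measured compound (the limit of > 50000 nM in this assay, at which 3 of the 3 values shown sit). The steps onto compound 3 are therefore unreadable in size: a step that the two limits leave unreadable from compound 1 to compound 3 and a step that the two limits leave unreadable from compound 2 to compound 3. Nothing in the measured set separates one compound from another in this read-out.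

Compound 4, `c1ccn2c(NC3CCCC3)c(-c3nccs3)nc2c1`, differs from compound 3 by 1,3-thiazol-2-yl in place of 2-fluorophenyl on an aromatic carbon. Among the compounds with values here, no measured step bears on this change with a readable size, since the two steps onto compound 3 are both capped by the limit. Given that every measured analogue, whatever the aryl group, sits at the limit (the limit of > 50000 nM in this assay, at which 3 of the 3 values shown sit), compound 4 is expected to sit there as well, and the step that the limit leaves unreadable from compound 3 to compound 4 is estimated to be nothing beyond the scatter. Compound 4 is therefore estimated at 80000 nM in this assay, in the range 30000 nM to 300000 nM, most likely reported again as a limit.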

Compound 4, half-maximal cytotoxic concentration: > 50000 nM
Compound 4 was reported as a limit (the forecaster's own chance of this, stated with the estimate: 75%); the middle value lies beyond the limit too.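

Compound 4 joins compound 1, compound 2 and compound 3 at a limit, so the size of the steps from compound 1, compound 2 and compound 3 to compound 4 cannot be read: the limit of > 50000 nM in this assay, at which 4 of the 4 values shown sit.

Left open is whether these four compounds differ at all in this read-out, and which change to the shared core would give a measurable value.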